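Branching at the Propargylic Carbon of an Alkyne Diester

This account rests on a few compounds, and the source may have more. Where it says the series, first, only, none or still open, it means among the compounds named here.

Compound 1 `COC(=O)C#CC(CC(C)C)O/C=C/C(=O)OC` is the most active of three compounds tested in a functional assay on HBL-100 cells (Homo sapiens) for antiproliferative activity, read by sulforhodamine B assay, with a stated time of 48 h (on this read-out higher numbers stand for weaker inhibition of growth and lower numbers for stronger inhibition of growth), where compound 1 gives 330 nM. Compound 2 `CC(C)C(C#CC(=O)OC(C)(C)C)O/C=C/C(=O)OC(C)(C)C` gives 3000 nM and compound 3 `Cc1ccc(S(=O)(=O)C#CC(O/C=C/S(=O)(=O)c2ccc(C)cc2)C(C)C)cc1` gives 3800 nM; both gaps from compound 1 lie beyond the usual scatter. Compound 4 `COC(=O)C#CC(O/C=C/C(=O)OC)C(C)(C)C` has not yet been measured. It differs from compound 1 in one place: tert-butyl in place of isobutyl on a saturated chain carbon bound to an oxygen on an unsaturated carbon and a triple-bonded carbon. Among the compounds with values here, no measured pair shows this exact change, so nothing in the data fixes its size; the step in this assay is expected to be small, most likely within the scatter, with a slight lean toward weaker inhibition. Compound 4 is therefore expected to give about 500 nM, within a range from 150 nM to 1800 nM, which means an expected step of a 1.5-fold higher number from compound 1 to compound 4 (0.18 log units; within the scatter).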

Compound 4, concentration for 50% growth inhibition: 1800 nM
Compound 4: middle estimate off by 3.6-fold (0.56 log units), on the low side, and the stated range covers the measured number.
By their numbers in this assay, from the lowest: compound 1; then compounds 4, 2 and 3 (each within the scatter of the next, the first and the last beyond it).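

In this assay, within the data shown here, the step is a 5.5-fold higher number from compound 1 to compound 4 (0.74 log units; beyond the scatter) and it is the first change in the set made in one place only. Isobutyl and tert-butyl hold the same four carbons, so how those carbons are joined on this saturated chain carbon matters to growth inhibition, even with the atom count unchanged. No measurement shown gives a reason for this step.

As far as these compounds go, whether a straight butyl chain, a longer chain or a phenyl ring at this carbon would match compound 1 remains open.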